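The source may report more compounds than this note shows. Statements on the series, on what has been measured and on what is new or still open speak of the compounds shown alone.

Compound 1 `CCOc1cc([C@](O)(CCN(C)C)[C@@H](c2cc3cc(Br)ccc3nc2OC)c2cccc(OC)c2F)cc(OC)n1` gives 14 uL/min in an ADME assay on microsomes from liver (Mus musculus) for metabolic stability (a higher number here means faster removal of the compound, a lower number slower removal), the highest of the three numbers, though compound 2 `CCOc1cc([C@](O)(CCN(C)C)[C@H](c2cccc(C)c2)c2cc3cc(Br)ccc3nc2OC)cc(OC)n1` with 7.8 uL/min and compound 3 `CCOc1cc([C@](O)(CCN(C)C)[C@@H](c2cc3cc(Br)ccc3nc2OC)c2ccnc(OC)c2OC)cc(OC)n1` with 7.6 uL/min both sit within the scatter of it. The two steps from compound 1, a 1.8-fold lower number from compound 1 to compound 2 (0.25 log units; within the scatter) and a 1.8-fold lower number from compound 1 to compound 3 (0.27 log units; within the scatter), alter the group on a saturated chain carbon bound to an aromatic carbon and a saturated chain carbon, a different place from the one changed here. Compound 4 `COc1cc([C@](O)(CCN(C)C)[C@@H](c2cc3cc(Br)ccc3nc2OC)c2cccc(OC)c2F)cc(OC(C)C)n1` differs from compound 1 as follows: methyl in place of hydrogen on a saturated chain carbon bound to an oxygen on an aromatic ring and a saturated chain carbon. Going by the values given here, no measured step touches this position, so nothing argues for a shift beyond the scatter in this assay in either direction. Compound 4 is therefore expected at 14 uL/min, with a range from 7 uL/min to 28 uL/min, which is an expected step of no change at the digits printed from compound 1 to compound 4 (within the scatter).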

Compound 4, intrinsic clearance in a liver preparation (reported as CLH), per the amount of preparation that the assay uses: 6 uL/min
Estimate against measurement, compound 4: 2.3-fold (0.37 log units) above; the whole stated range lies above it.
By their numbers in this assay, from the lowest: compounds 4, 3, 2 and 1 (each within the scatter of the next, the first and the last beyond it).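

Ethoxy to isopropoxy is the first change shown at this position, and in this assay it gives a 2.3-fold lower number from compound 1 to compound 4 (0.37 log units; beyond the scatter) and so the position responds to one added methyl, modestly but beyond the scatter. The steps at the other place, on the saturated chain carbon bound to an aromatic carbon, all stayed within the scatter and could not show this. Nothing available explains the shift. Going by these compounds, whether a cyclopropyl group or a longer chain here would go further remains open. So does whether the same step holds with the 3-methylphenyl group of compound 2 or the 2,3-dimethoxypyridin-4-yl group of compound 3.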